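Changing the Aryl Group on the Amine Side Chain

The source may hold more compounds than are shown below. What is called first, only, known or untested is meant among the compounds shown, and "the series" means these compounds.

Compound 1 `O=S(=O)(NCCCNCc1ccccc1Cl)c1cc(C(F)(F)F)cc(C(F)(F)F)c1`: 13000 nM
Compound 2 `CC(C)(C)c1ccc(CNCCCNS(=O)(=O)c2cc(C(F)(F)F)cc(C(F)(F)F)c2)cc1`: 2100 nM
Compound 3 `O=S(=O)(NCCCNCc1ccc(Cl)c(Cl)c1)c1cc(C(F)(F)F)cc(C(F)(F)F)c1`: 1800 nM

In a functional assay on Capan-2 cells (Homo sapiens) for inhibition, read by MTT assay, with a stated time of 72 h (on this read-out lower numbers stand for stronger inhibition of growth and higher numbers for weaker inhibition of growth), compound 3 has the lowest number of the three, but the gap to compound 2 lies within the scatter (a 1.2-fold lower number from compound 2 to compound 3 (0.07 log units; within the scatter)), so the two cannot be ranked. Two steps lie beyond the scatter: a 6.2-fold lower number from compound 1 to compound 2 (0.79 log units; beyond the scatter) and a 7.2-fold lower number from compound 1 to compound 3 (0.86 log units; beyond the scatter). Compound 4 `COc1ccc(CNCCCNS(=O)(=O)c2cc(C(F)(F)F)cc(C(F)(F)F)c2)cc1OC` carries 3,4-dimethoxyphenyl in place of 3,4-dichlorophenyl on a saturated chain carbon bound to an amine nitrogen. Going by the values given here, the measured steps at this position show only that replacing 2-chlorophenyl lowered the number; no measured pair contains a methoxy group, so the direction for compound 4 is open. A modest rise is expected, a 2.5-fold higher number from compound 3 to compound 4 (0.40 log units; beyond the scatter), and compound 4 is estimated at 4500 nM with a range of 1200 nM to 16000 nM.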

Compound 4, concentration for 50% growth inhibition: 15000 nM
Compound 4: middle estimate off by 3.3-fold (0.52 log units), on the low side; low and high end bracket the measured number.
By their numbers in this assay, from the lowest: compounds 3 and 2 (each within the scatter of the next); then compounds 1 and 4 (each within the scatter of the next).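

In this assay, the change to 3,4-dimethoxyphenyl gives an 8.3-fold higher number from compound 3 to compound 4 (0.92 log units; beyond the scatter) and a 7.1-fold higher number from compound 2 to compound 4 (0.85 log units; beyond the scatter), whereas a 1.2-fold higher number from compound 1 to compound 4 (0.06 log units; within the scatter), so compound 4 cannot be told apart from compound 1. The position therefore does not reward every replacement of 2-chlorophenyl, and the shared pattern of substitution does not by itself set the number, since 3,4-dichlorophenyl and 3,4-dimethoxyphenyl differ clearly. No available evidence accounts for this difference.

As far as these compounds go, it remains open whether a phenyl ring carrying a single methoxy group, or a hydroxyl group or an amine in place of methoxy, would match compound 3 or compound 4.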